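Iodo for propyl on the cinnamamide phenyl ring

The source may report more compounds than this note shows. Statements on the series, on what has been measured and on what is new or still open speak of the compounds shown alone.

Three compounds have been measured in a functional assay on HEK293 cells for activation of melanin-concentrating hormone receptor 1 (Homo sapiens), read by inositol phosphate accumulation; a lower number here means that less compound is needed, a higher number that more compound is needed for the effect:

Compound 1, `CCCc1cc(NC)c2cc(NC(=O)/C=C/c3ccc(C(F)(F)F)cc3)ccc2n1`: 150 nM
Compound 2, `CCCc1cc(OC)c2cc(NC(=O)/C=C/c3ccc(C(F)(F)F)cc3)ccc2n1`: 360 nM
Compound 3, `CCCc1ccc(/C=C/C(=O)Nc2ccc3nc(CCC)cc(N)c3c2)cc1`: 3600 nM

Compound 3 gives the highest number of the three, so more of it is needed than of compound 1 or compound 2. Within the data shown here, the only single-change step among the measured compounds is a 2.4-fold higher number from compound 1 to compound 2 (0.38 log units; beyond the scatter), which concerns the group on the shared core and not the phenyl ring that carries the change now in question.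

Compound 4, `CCCc1cc(N)c2cc(NC(=O)/C=C/c3ccc(I)cc3)ccc2n1`, differs from compound 3 in one place: iodo in place of propyl on an aromatic carbon. Among the measured compounds shown here, no measured pair isolates this change. Compound 1 and compound 2 carry trifluoromethyl where compound 3 has propyl, but they also differ from compound 3 in the group on the core, so their lower numbers cannot be split between the two differences. With this gap in the data, the direction is uncertain; because compound 3 gives 3600 nM while both trifluoromethyl compounds give lower numbers, a lower number for compound 4 is expected, with the step of a 3.6-fold lower number from compound 3 to compound 4 (0.56 log units; beyond the scatter). Compound 4 is therefore estimated at 1000 nM, within a range of 250 nM to 4000 nM.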

Compound 4, half-maximal effective concentration: 280 nM
Compound 4: the middle estimate sits 3.6-fold (0.55 log units) above what was measured, within the range that was stated.
By their numbers in this assay, from the lowest: compounds 1, 4 and 2 (each within the scatter of the next, the first and the last beyond it); then compound 3.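

With the rest of the molecule unchanged, iodo in place of propyl gives a 13-fold lower number from compound 3 to compound 4 (1.11 log units; beyond the scatter) in this assay, so less compound is needed for the effect. Among these compounds, this is the first step measured at this position on the phenyl ring, as the only earlier step, a 2.4-fold higher number from compound 1 to compound 2 (0.38 log units; beyond the scatter), concerned the group on the shared core. It shows that the effect in this assay depends strongly on what this ring position carries, even though the change only replaces the 3 carbon atoms of propyl with 1 iodine atom, and nothing measured here explains the size of the step.

The compounds shown leave open whether the lower number comes from having iodo or simply from losing propyl, a question that hydrogen, chlorine or methyl at this position on the same core could help settle. They also leave open how trifluoromethyl would compare with iodo when the core is held the same, and how a longer chain such as butyl or a polar group such as an amine would behave here.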